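Methoxy for Chloro on Two Selenium-Bearing Cores

The compounds below may be only part of what the source reports. "The series", "measured", "known", "first", "only" and "open" are said of these compounds alone.

Compound 1 `NC(=[Se])N/N=C/c1ccc(Cl)cc1` gives 8630 nM in a functional assay on DU-145 cells (Homo sapiens) for cytotoxicity, read by XTT assay, with a stated time of 72 h; on this read-out lower numbers stand for stronger inhibition and higher numbers for weaker inhibition. Compound 2 `COc1ccc(/C=N/NC(N)=[Se])cc1` carries methoxy in place of chloro on an aromatic carbon, and in this assay compound 2 gives 30300 nM, a step of a 3.5-fold higher number from compound 1 to compound 2 (0.55 log units; beyond the scatter). Compound 3 `Cc1c[se]c(N/N=C/c2ccc(Cl)cc2)n1` rests on a different core; the difference between the two cores is not broken down here. In this assay compound 3 gives 49400 nM, beyond the scatter from compound 1 but within the scatter of compound 2. Compound 4 `COc1ccc(/C=N/Nc2nc(C)c[se]2)cc1` is not yet measured and carries the same kind of change, (methoxy in place of chloro on an aromatic carbon), here para to a group of 9 heavy atoms rather than a group of 6 heavy atoms. Within the data shown here, the step from compound 3 to compound 4 is expected to be a 3.0-fold higher number from compound 3 to compound 4 (0.48 log units; beyond the scatter) because a 3.5-fold higher number from compound 1 to compound 2 (0.55 log units; beyond the scatter) is the only precedent for this change. Compound 4 is therefore estimated at 150000 nM, with a range from 50000 nM to 400000 nM.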

Compound 4, half-maximal inhibitory concentration: > 84900 nM
Compound 4: only a limit was reported; the forecaster's own chance of this, stated with the estimate: 35%; the middle value lies beyond the limit too.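

In this assay compound 4 gives > 84900 nM, which is a limit of the assay and not a number. Methoxy in place of chloro on the second core can therefore be read only as a floor, an at least 1.7-fold higher number from compound 3 to compound 4 (0.23 log units; that floor lies within the scatter), and that floor alone does not establish a step beyond the scatter. The change is compatible with carrying over from one core to the other, but neither a matching size nor a different one is shown: the same change on two cores in this assay, a 3.5-fold higher number (0.55 log units; beyond the scatter) from compound 1 to compound 2 and an at least 1.7-fold higher number (0.23 log units; that floor lies within the scatter) from compound 3 to compound 4; the limit leaves it open whether they differ

The compounds shown place only chloro and methoxy on the aromatic ring, on just these two cores. As far as these compounds go, how an amine, a carboxylic acid or a longer alkoxy chain would read at that place remains open.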